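Swapping an Aryl End Group on a Second Core

This account rests on a few compounds, and the source may have more. Where it says the series, first, only, none or still open, it means among the compounds named here.

Compound 1 `Cc1ccc2[nH]c(-c3ccc(-c4ccc(-c5ccc(N(C)C)cc5)cc4)cc3)nc2c1` and compound 2 `Cc1ccc2[nH]c(-c3ccc(-c4ccc(-c5cccc(Cl)c5)cc4)cc3)nc2c1` share one core and differ only at the far end: 3-chlorophenyl in place of 4-(dimethylamino)phenyl on an aromatic carbon. In a functional assay on A2780 cells (Homo sapiens) for inhibition, read by sulforhodamine B assay (a higher number here means a weaker inhibitor of growth, a lower number a stronger inhibitor of growth), compound 1 gives 2210 nM and compound 2 gives 2800 nM, a step of a 1.3-fold higher number from compound 1 to compound 2 (0.10 log units; within the scatter). Compound 3 `CN(C)c1ccc(-c2ccc(-c3ccc(-c4nc5c(O)cccc5[nH]4)cc3)cc2)cc1` carries a different core, described by 4-hydroxy-1H-benzimidazol-2-yl in place of 5-methyl-1H-benzimidazol-2-yl on an aromatic carbon, and in this assay compound 3 gives 3010 nM, a step of a 1.4-fold higher number from compound 1 to compound 3 (0.13 log units; within the scatter). Compound 4 `Oc1cccc2[nH]c(-c3ccc(-c4ccc(-c5cccc(Cl)c5)cc4)cc3)nc12` is the unmeasured partner of compound 3, reached by the same change: 3-chlorophenyl in place of 4-(dimethylamino)phenyl on an aromatic carbon. Because a 1.3-fold higher number from compound 1 to compound 2 (0.10 log units; within the scatter) is the step seen for this same change on the first core, and the place is described identically for both pairs, the step is expected to be about a 1.3-fold higher number from compound 3 to compound 4 (0.10 log units; within the scatter). Compound 4 is therefore expected to give 3800 nM in this assay, most likely between 1900 nM and 7600 nM.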

Compound 4, concentration for 50% growth inhibition: 2800 nM
Beside the measured number, compound 4's estimate is 1.4-fold (0.13 log units) above it; measured number inside the range.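

On the core of compound 3, 3-chlorophenyl in place of 4-(dimethylamino)phenyl gives a 1.1-fold lower number from compound 3 to compound 4 (0.03 log units; within the scatter) in this assay. Set beside the same change on the first core, the two steps agree: the same change on two cores in this assay, a 1.3-fold higher number (0.10 log units; within the scatter) from compound 1 to compound 2 and a 1.1-fold lower number (0.03 log units; within the scatter) from compound 3 to compound 4, 1.4-fold (0.13 log units) apart, within the scatter of two such steps. This shows that the swap left the number within the scatter on both cores, but because neither step is larger than the scatter, it does not show that a change with a real effect would carry from one core to the other.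

The compounds shown leave open whether another end group, such as a carboxylic acid or a longer chain ending in an amine, would give a step beyond the scatter. On these data alone, whether such a step would then be the same on both cores also remains open.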